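A few compounds are considered here, and "the series" means these few. Any claim that something is new, unique, unknown or untested is made for them only; others in the source may bear on it.

Measured so far in an ADME assay on Huh-7 cells (Homo sapiens) for cytotoxicity, with a stated time of 72 h; on this read-out higher numbers stand for lower toxicity in this test and lower numbers for higher toxicity in this test:

- compound 1 `CS(=O)(=O)Nc1ccc2c(c1)S(=O)(=O)N=C(c1c(O)c(-c3ccc(Cl)s3)nn(CCC3CC3)c1=O)N2`: > 33000 nM
- compound 2 `C/C(=C\c1nn(CCC(C)C)c(=O)c(C2=NS(=O)(=O)c3cc(NS(C)(=O)=O)ccc3N2)c1O)C(F)(F)F`: > 33000 nM
- compound 3 `COC(C)(C)CCn1nc(-c2cccs2)c(O)c(C2=NS(=O)(=O)c3cc(NS(C)(=O)=O)ccc3N2)c1=O`: > 33000 nM

All three entries are limits of the assay and not numbers. Compound 3 stands with the other two, and the record so far is simple: the limit of > 33000 nM in this assay, at which 3 of the 3 values shown sit.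

The next structure is compound 4 `CS(=O)(=O)Nc1ccc2c(c1)S(=O)(=O)N=C(c1c(O)c(-c3cccs3)nn(CC3CC3)c1=O)N2`. The change from compound 3 is cyclopropyl in place of 2-methoxy-2-methylpropyl on a saturated chain carbon bound to an aromatic nitrogen. In words, cyclopropyl takes the place of 2-methoxy-2-methylpropyl on a saturated chain carbon bound to an aromatic nitrogen. Cut one bond further out, the same difference reads 3-methoxy-3-methylbutyl to cyclopropylmethyl.

Within the data shown here, no pair of measured compounds differing in one place is available, so the size of this step has not been observed directly. The expectation therefore rests on the shared position of the measured compounds in this assay, as the limit of > 33000 nM in this assay, at which 3 of the 3 values shown sit. No shift beyond the scatter is expected, in either direction. The expected step is a number no higher from compound 3 to compound 4 (the limit leaves the size open). For compound 4 the estimated value is 33000 nM, with an expected range from 18000 nM to 50000 nM.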

Compound 4, half-maximal cytotoxic concentration: > 1000 nM
Compound 4 ended at the assay's limit (the forecaster's own chance of this, stated with the estimate: 85%); the middle value is on the limit's open side.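

Among these compounds, the entries for compound 3 and compound 4 are both limits of the assay and not numbers, so no step between these two compounds can be read. The compounds shown leave open the actual half-maximal cytotoxic concentration of each compound, and whether cyclopropyl in place of 2-methoxy-2-methylpropyl shifts it at all.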